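This account rests on a few compounds, and the source may have more. Where it says the series, first, only, none or still open, it means among the compounds named here.

Of the compounds shown here, two have measured values so far. Compound 1 `O=C(O)/C=C/c1ccc(/C(=C(\c2ccccc2)C2CCC2)c2ccc3[nH]ncc3c2)cc1` gives 1.4 nM in a functional assay on MCF7 cells (Homo sapiens) for cytotoxicity, read by CellTiter-Glo, with a stated time of 5 days; a lower number here means a stronger inhibitor, a higher number a weaker inhibitor. Within the data shown here, compound 2 `CC/C(=C(/c1ccc(/C=C/C(=O)O)cc1)c1cc2cn[nH]c2cn1)c1ccccc1` gives 442 nM in this assay, the highest of the two numbers; its only neighbour is compound 1, which sits far lower, well beyond the scatter. The two differ in more than one place, so no single step can be read between them.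

Compound 3 `CC/C(=C(/c1ccc(/C=C/C(=O)O)cc1)c1cc(C)c2[nH]ncc2c1)c1ccccc1` has not yet been measured. It differs from compound 2 in one place: a group of 10 heavy atoms (8 carbon, 2 nitrogen; one five-membered aromatic ring with 2 hetero atoms, one six-membered aromatic ring of carbon only) in place of a group of 9 heavy atoms (6 carbon, 3 nitrogen; one five-membered aromatic ring with 2 hetero atoms, one six-membered aromatic ring with 1 hetero atom), on a double-bonded chain carbon bound to an aromatic carbon and a double-bonded chain carbon. Among the measured compounds shown here, the group that enters is of the same kind as the one borne by compound 1, while the rest of compound 3 stays as in compound 2. For the measured compounds named here, no measured pair isolates this exchange, so its size is not known from a direct step. Because compound 1 gives 1.4 nM with a closely related group at this position, a large step toward a lower number is expected from compound 2 to compound 3, estimated at a 37-fold lower number from compound 2 to compound 3 (1.57 log units; beyond the scatter). Compound 3 is therefore expected to give about 12 nM in this assay, with a plausible range from 2 nM to 70 nM.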

Compound 3, half-maximal inhibitory concentration: 59 nM
Compound 3: the middle estimate sits 4.9-fold (0.69 log units) below what was measured; the measured number falls inside the stated range.
By their numbers in this assay, from the lowest: compound 1; then compound 3; then compound 2.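

In this assay, among these compounds, replacing the group of compound 2 with 7-methyl-1H-indazol-5-yl gives a 7.5-fold lower number from compound 2 to compound 3 (0.87 log units; beyond the scatter), the first step that can be read at a single place, and it shows that the group on this double-bonded chain carbon alone moves the number beyond the scatter. The exchange alters more than one feature at once: the group entering has one more heavy atom, one fewer nitrogen, a six-membered aromatic ring of carbon only, and one fewer hydrogen-bond acceptor, while the donor count stays the same, so the step cannot be divided among these features. No measured property is available to explain the step.

The compounds shown do not reveal whether the methyl of 7-methyl-1H-indazol-5-yl contributes to the step, nor how a 7-chloro-1H-indazol-5-yl or 7-ethyl-1H-indazol-5-yl group would compare at this place. From the compounds shown here alone, compound 1 differs from compound 3 in more than one place, so no step can be read between them, and the part played by the cyclobutyl group of compound 1 remains open.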